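Adding Bromine to a Sugar-Linked Diketone with Low Toxicity

A few compounds are considered here, and "the series" means these few. Any claim that something is new, unique, unknown or untested is made for them only; others in the source may bear on it.

Compound 2 `CC(=O)O[C@@H]1[C@H]2OC(C)(C)O[C@H]2O[C@@H]1C(=O)c1cnc2sc(C(=O)c3ccccc3)cn12` is the starting point. In an ADME assay on Vero cells (Chlorocebus sabaeus) for cytotoxicity, read by MTT assay, with a stated time of 48 h (on this read-out higher numbers stand for lower toxicity in this test and lower numbers for higher toxicity in this test), compound 2 shows only a limit of the test, > 400000 nM, which is the limit of > 400000 nM in this assay, at which 1 of the 2 values shown sits. A related compound 1 `CO[C@@H]1[C@H]2OC(C)(C)O[C@H]2O[C@@H]1C(=O)c1cnc2sc(C(=O)c3ccc(Br)cc3)cn12` already carries a bromine and gives 295000 nM in this assay. Compound 3 `CC(=O)O[C@@H]1[C@H]2OC(C)(C)O[C@H]2O[C@@H]1C(=O)c1cnc2sc(C(=O)c3ccc(Br)cc3)cn12` arises from compound 2 by one change: bromo in place of hydrogen on an aromatic carbon. Among the compounds with values here, no measured pair shows this change directly. Compound 1, through its 295000 nM, suggests compound 3 stays in the same low-toxicity region. Compound 3 is therefore expected at 300000 nM, between 150000 nM and 400000 nM. The expected step is an at least 1.3-fold lower number from compound 2 to compound 3 (0.12 log units; that floor lies within the scatter), none beyond the scatter.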

Compound 3, half-maximal cytotoxic concentration: 139000 nM
For compound 3 the middle estimate is 2.2-fold (0.33 log units) above the measured one; measured number outside the range, below it.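

In this assay bromo in place of hydrogen gives an at least 2.8-fold lower number from compound 2 to compound 3 (0.45 log units; beyond the scatter) on this ring, so the bromine moves the number even with the acetyl group present. This step has only a floor, because compound 2 stands at a limit of the test: the limit of > 400000 nM in this assay, at which 1 of the 3 values shown sits. With the bromine kept, acetyl in place of methyl on the oxygen gives a 2.1-fold lower number from compound 1 to compound 3 (0.33 log units; beyond the scatter) as well, so the group on that oxygen also shifts the number.

Still open, from the compounds shown here alone, is whether an amine or a carboxylic acid in place of the bromine would shift the number in the same direction. Also open, going by these compounds, is how large the bromo step is with methyl on that oxygen.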